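Moving the Fluorine on the Benzamide Ring

A few compounds are considered here, and "the series" means these few. Any claim that something is new, unique, unknown or untested is made for them only; others in the source may bear on it.

Measured in a functional assay on HepG2 cells (Homo sapiens) for inhibition, read by MTT assay (a higher number here means a weaker inhibitor, a lower number a stronger inhibitor), so far:
- Compound 1 `COc1cc2ncnc(Nc3ccc(NC(=O)c4ccccc4OC)cc3)c2cc1OC` gives > 100000 nM as a limit of the assay.
- Compound 2 `COc1cc2ncnc(Nc3ccc(NC(=O)c4ccc(C(C)(C)C)cc4)cc3)c2cc1OC` gives > 100000 nM as a limit of the assay.
- Compound 3 `COc1cc2ncnc(Nc3ccc(NC(=O)c4cccc(F)c4)cc3)c2cc1OC` gives 8200 nM as a true number.

Compound 3 alone has a number, and it lies well under both limits. Compound 4 `COc1cc2ncnc(Nc3ccc(NC(=O)c4ccc(F)cc4)cc3)c2cc1OC` differs from it thus: 4-fluorophenyl in place of 3-fluorophenyl on a carbonyl carbon with 4-fluorophenyl in place of 3-fluorophenyl on a carbonyl carbon. Going by the values given here, two measured steps bear on this: an at least 12-fold lower number from compound 1 to compound 3 (1.08 log units; beyond the scatter) and an at least 12-fold lower number from compound 2 to compound 3 (1.08 log units; beyond the scatter) show that this group can matter greatly. Neither compares two fluorophenyl groups, so the range stays wide. The expected step is a 1.7-fold higher number from compound 3 to compound 4 (0.23 log units; within the scatter) and so a small one. Compound 4 is estimated at 14000 nM with a range of 3500 nM to 70000 nM as expected bounds.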

Compound 4, half-maximal inhibitory concentration: 15000 nM
For compound 4 the middle estimate is 1.1-fold (0.03 log units) below the measured one; low and high end bracket the measured number.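

Moving the fluorine from 3-fluorophenyl to 4-fluorophenyl on the carbonyl carbon gives a 1.8-fold higher number from compound 3 to compound 4 (0.26 log units; within the scatter), so this assay does not separate these two groups. Against the other two groups the steps are an at least 6.6-fold lower number from compound 2 to compound 4 (0.82 log units; beyond the scatter) and an at least 6.6-fold lower number from compound 1 to compound 4 (0.82 log units; beyond the scatter), so a readable number now holds for two fluorophenyl groups, not one. These sizes are only lower bounds because compound 1 and compound 2 each carry a limit: the limit of > 100000 nM in this assay, at which 2 of the 4 values shown sit.

As far as these compounds go, whether plain phenyl or 4-chlorophenyl would also give a readable number stays open. So does the outcome for 2-fluorophenyl, the one fluorophenyl group not among these compounds.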